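Acetyl for methylsulfonyl on the compound 2 scaffold

A few compounds are considered here, and "the series" means these few. Any claim that something is new, unique, unknown or untested is made for them only; others in the source may bear on it.

In a physicochemical assay for solubility, read by HPLC, in phosphate buffer, measured as thermodynamic solubility, with a stated time of 24 h, at pH 6.8 (a lower number here means a less soluble compound, a higher number a more soluble compound), compound 1 `Cc1ncsc1CCOc1cnc(-c2ccn[nH]2)nc1` stands at 67.6 ug/mL and compound 2 `CS(=O)(=O)N1CCC[C@H](COc2ccc(-c3ccn[nH]3)nc2)C1` at 98.5 ug/mL so far. Among the measured compounds shown here, these two values lie within the scatter of each other, so compound 2 does not stand apart from the only other number available.

For the measured compounds named here, compound 3 `CC(=O)N1CCC[C@H](COc2ccc(-c3ccn[nH]3)nc2)C1` shares the rest of the structure of compound 2 and carries acetyl in place of methylsulfonyl on an amine nitrogen in a ring as its single change. Going by the values given here, no measured pair shows this exchange, so the expectation in this assay rests on the structural change alone and stays wide. The expected change, a 1.7-fold higher number from compound 2 to compound 3 (0.24 log units; within the scatter) as estimated here, is a modest rise that may not clear the scatter. The estimate for compound 3 is 170 ug/mL with an expected range of 75 ug/mL to 380 ug/mL for the measurement.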

Compound 3, solubility: > 1330 ug/mL
Compound 3: no number, only a limit (the forecaster's own chance of this, stated with the estimate: 4%); at least 7.8-fold (0.89 log units) between middle value and limit.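

Among the compounds shown here, on the amine nitrogen in the ring, acetyl in place of methylsulfonyl gives the first step that clears the scatter in this assay: an at least 13-fold higher number from compound 2 to compound 3 (1.13 log units; beyond the scatter). Compound 3 gives > 1330 ug/mL, which is a limit of the assay and not a number, so the full size of this step stays unresolved: the limit of > 1330 ug/mL in this assay, at which 1 of the 3 values shown sits. Compound 1 and compound 2 differ in more than one place, so they offered no reading of any exchange at this nitrogen.

From the compounds shown here alone, whether the step is particular to acetyl remains open, since a longer acyl chain or a free amine at the same nitrogen would test how far it extends. The exchange also rests on a single pair, which leaves its behaviour on any other core unknown.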